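The source may hold more compounds than are shown below. What is called first, only, known or untested is meant among the compounds shown, and "the series" means these compounds.

In a functional assay on the whole organism (strain CD-1) with Mus musculus as the target, with a stated time of 2 h (on this read-out higher numbers stand for an effect only at larger amounts of compound and lower numbers for an effect already at smaller amounts), the series is built on a shared core carrying a piperazine-linked aryl group. Compound 1 `CC1(c2ccccc2)CC(=O)N(CC(=O)N2CCN(c3ccc(Cl)cc3)CC2)C1=O` gives 300 mg/kg in this assay. For the measured compounds named here, compound 2 `Cc1cccc(N2CCN(C(=O)CN3C(=O)CC(C)(c4ccccc4)C3=O)CC2)c1` is reported in this assay as "not active" (no number reported), so no single number marks where it stands, and it cannot be placed against compound 1 on the numerical scale; the two values show only that compound 1 produced an effect at the dose tested while compound 2 did not.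

Compound 3 `COc1cccc(N2CCN(C(=O)CN3C(=O)CC(C)(c4ccccc4)C3=O)CC2)c1` differs from compound 2 in one place: methoxy in place of methyl on an aromatic carbon. The change is small in count, and the site is the aromatic carbon meta to the large group on the six-membered aromatic ring of carbon only.

Going by the values given here, with no measured pair to anchor a step size, the expectation for this assay is that compound 3 will behave much like compound 2, with any difference likely within the scatter rather than a clear shift toward activity at smaller doses. For compound 3 the estimated value in this assay is 300 mg/kg, within a range of 100 mg/kg to 1000 mg/kg, and it is expected that the assay may again report no number at all.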

Compound 3, minimum effective dose: "not active" (no number reported)
No number was reported for compound 3; the estimate stays without a comparison.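

In this assay compound 2 and compound 3 both carry the report "not active" without a number, so no step can be read between them. As far as these compounds go, whether going from 3-methylphenyl to 3-methoxyphenyl shifts the dose needed for an effect stays open. No supporting evidence bears on this result.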